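Dithiocarbamate amine variation: pyrrolidinyl replacing the pyridinylmethyl amine

The source may report more compounds than this note shows. Statements on the series, on what has been measured and on what is new or still open speak of the compounds shown alone.

For the measured compounds named here, compound 2 `CCN(Cc1ccncc1)C(=S)SCc1ccc(C(=O)Nc2ccccc2N)cc1` stands highest of the three measured members in a functional assay on MGC-803 cells (Homo sapiens) for antiproliferative activity, read by CCK-8 assay, with a stated time of 72 h, tested at 2 uM (on this read-out lower numbers stand for a weaker effect and higher numbers for a stronger effect at the one concentration tested), with 71.6%. Compound 1 `Nc1ccccc1NC(=O)c1ccc(CSC(=S)N2CCCc3ccccc32)cc1` gives 38.5% in this assay, and compound 3 `Cc1ccc(N2CCN(C(=S)SCc3ccc(C(=O)Nc4ccccc4N)cc3)CC2)cc1` gives 33.4%. Going by the values given here, the one single-point step measured so far, a number 33.1 percentage points higher from compound 1 to compound 2 (beyond the scatter), shows that an open-chain amine bearing a pyridine carried a much stronger effect than a fused bicyclic cyclic amine on the thiocarbonyl carbon.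

Compound 4 `Nc1ccccc1NC(=O)c1ccc(CSC(=S)N2CCCC2)cc1` is not yet measured. It differs from compound 2 as follows: pyrrolidin-1-yl in place of ethyl((pyridin-4-yl)methyl)amino on a thiocarbonyl carbon. The change returns to a cyclic amine without an aromatic ring, the class to which compound 1 and compound 3 belong, both of which sit well under compound 2. The step from compound 1 to compound 2 therefore bears most directly, in reverse, and a downward step beyond the scatter is expected, a number 31.6 percentage points lower from compound 2 to compound 4 (beyond the scatter). Compound 4 is expected to give about 40% in this assay, within 22% to 60%.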

Compound 4, a percentage reported as inhibition, at one concentration (the size of the read-out at that concentration, not a potency): 27%
Estimate against measurement, compound 4: 13 percentage points above; measured number inside the range.
By their numbers in this assay, from the lowest: compounds 4, 3 and 1 (each within the scatter of the next, the first and the last beyond it); then compound 2.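

In this assay, pyrrolidin-1-yl on the thiocarbonyl carbon gives a number 44.6 percentage points lower from compound 2 to compound 4 (beyond the scatter), which extends the low-number group to a cyclic amine with one five-membered non-aromatic ring and no aromatic ring. The change among cyclic amines also registers, with a number 11.5 percentage points lower from compound 1 to compound 4 (beyond the scatter), so this position distinguishes pyrrolidin-1-yl from 1,2,3,4-tetrahydroquinolin-1-yl, though by a modest step. No data bearing on the origin of either step are at hand.

For the compounds shown here, compound 2 remains the only compound here with an open-chain amine or a pyridine, so the two features cannot be separated; a benzyl(ethyl)amino group or a diethylamino group on the thiocarbonyl carbon would address this. Also open, from the compounds shown here alone, is how a cyclic amine carrying a pyridine, such as 4-(pyridin-4-yl)piperazin-1-yl, would compare.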